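The compounds below may be only part of what the source reports. "The series", "measured", "known", "first", "only" and "open" are said of these compounds alone.

Measured so far in a functional assay on OVCAR-4 cells (Homo sapiens) for inhibition; a lower number here means a stronger inhibitor of growth, a higher number a weaker inhibitor of growth
Compound 1 `COc1cc(/C=C/c2ccc(S(N)(=O)=O)cc2)cc(OC)c1` gives 21200 nM
Compound 2 `NS(=O)(=O)c1ccc(/C=C/c2ccc(O)c(O)c2)cc1` gives 11600 nM
Compound 3 `NS(=O)(=O)c1ccc(/C=C/c2ccc(F)cc2)cc1` gives 34400 nM

Compound 3 (34400 nM) lies within the scatter of compound 1 (21200 nM) and has a higher number than compound 2 (11600 nM) by a gap beyond the scatter. Compound 4 `NS(=O)(=O)c1ccc(/C=C/c2ccc(O)cc2)cc1` has hydroxy in place of fluoro on an aromatic carbon, para to a large group (hydroxy in place of fluoro on an aromatic carbon). Among the measured compounds shown here, no measured pair differs in one place only, so this step has no direct precedent. For the measured compounds named here, the only measured compound with hydroxy groups is compound 2 (11600 nM), which suggests a modest shift at most. The expected change in this assay is small and toward a lower number, probably within the scatter (a 1.9-fold lower number from compound 3 to compound 4 (0.28 log units; within the scatter)). For compound 4 the estimated value is 18000 nM with an expected range from 7000 nM to 45000 nM in this read-out.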

Compound 4, concentration for 50% growth inhibition: 36900 nM
Compound 4: middle estimate off by 2.1-fold (0.31 log units), on the low side, within the range that was stated.
By their numbers in this assay, from the lowest: compounds 2, 1, 3 and 4 (each within the scatter of the next, the first and the last beyond it).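

In this assay, hydroxy in place of fluoro on an aromatic carbon, para to a large group, gives no change that can be told from the scatter (a 1.1-fold higher number from compound 3 to compound 4 (0.03 log units; within the scatter)). Among the compounds shown here, this is the first direct reading at this position, and here fluoro and hydroxy are interchangeable. Hydrogen in place of hydroxy on an aromatic carbon is a modest step beyond the scatter (a 3.2-fold higher number from compound 2 to compound 4 (0.50 log units; beyond the scatter)), so the extra hydroxy of compound 2 counts for more than this exchange, and nothing available explains either step.
Open, as far as these compounds go, is whether an amine or a carboxylic acid on this aromatic carbon would move this assay away from the level of compound 3 and compound 4.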